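This account rests on a few compounds, and the source may have more. Where it says the series, first, only, none or still open, it means among the compounds named here.

Compound 3 `CN(CCN1CCCCC1)c1ccc(Cn2c(=O)[nH]c3c(N)nc(C(F)(F)F)cc32)cn1` is measured in an in vitro ADME assay on microsomes from liver (Rattus norvegicus) for pharmacokinetics (on this read-out lower numbers stand for slow clearance and higher numbers for fast clearance), where compound 3 gives 13 mL.min-1.g-1. Compound 1 `CCN(CC)CCN(C)c1ccc(Cn2c(=O)[nH]c3c(N)nc(C(F)(F)F)cc32)cn1` gives 11 mL.min-1.g-1 in this assay. For compound 2 `Nc1nc(C(F)(F)F)cc2c1[nH]c(=O)n2Cc1ccc(NCCO)nc1` the result in this assay is a limit, < 8.5 mL.min-1.g-1. Of the two numbers, compound 3 sits at the top, yet a 1.2-fold higher number from compound 1 to compound 3 (0.07 log units; within the scatter) lies within the scatter. Compound 4 `CN1CCN(CCN(C)c2ccc(Cn3c(=O)[nH]c4c(N)nc(C(F)(F)F)cc43)cn2)CC1` is not yet measured; it differs from compound 3 by 4-methylpiperazin-1-yl in place of piperidin-1-yl on a saturated chain carbon, two bonds along the chain from a nitrogen on an aromatic ring. Within the data shown here, the only measured step at this place, a 1.2-fold higher number from compound 1 to compound 3 (0.07 log units; within the scatter), stays within the scatter, and the larger change an at least 1.5-fold higher number from compound 2 to compound 3 (0.18 log units; that floor lies within the scatter) does too, so no step beyond the scatter is expected in this assay. Compound 4 is expected to give 11 mL.min-1.g-1, within a range of 6 mL.min-1.g-1 to 20 mL.min-1.g-1. That estimate means an expected 1.2-fold lower number from compound 3 to compound 4 (0.07 log units; within the scatter).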

Compound 4, intrinsic clearance in microsomes: 15 mL.min-1.g-1
Compound 4: middle estimate off by 1.4-fold (0.13 log units), on the low side, and the stated range covers the measured number.
By their numbers in this assay, from the lowest: compounds 1, 3 and 4 (each within the scatter of the next). At a limit, below all of these: compound 2.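

At this chain end, 4-methylpiperazin-1-yl in place of piperidin-1-yl gives a 1.2-fold higher number from compound 3 to compound 4 (0.06 log units; within the scatter) in this assay, and in place of diethylamino it gives a 1.4-fold higher number from compound 1 to compound 4 (0.13 log units; within the scatter), so all three end groups now lie within the scatter of one another. Set against the (2-hydroxyethyl)amino group, the new side chain gives an at least 1.7-fold higher number from compound 2 to compound 4 (0.24 log units; that floor lies within the scatter). That step has only a floor, as compound 2 gives a limit and not a number: the limit of < 8.5 mL.min-1.g-1 in this assay, at which 1 of the 4 values shown sits.

Going by these compounds, whether a morpholine ring, a carboxylic acid or a longer chain would also stay within the scatter remains open. So does which part of these molecules sets their clearance.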